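A few compounds are considered here, and "the series" means these few. Any claim that something is new, unique, unknown or untested is made for them only; others in the source may bear on it.

Of the compounds shown here, two carry numbers so far. Compound 1 `O=C(CCc1nc2ccccc2c(=O)[nH]1)N/N=C/c1ccc(Cl)cc1` in a physicochemical assay, read by spectrophotometry, with a stated time of 30 min (a lower number here means a stronger inhibitor, a higher number a weaker inhibitor), gives 381000000 nM. Compound 2 `COc1ccc(/C=N/NC(=O)CCCc2nc3ccccc3c(=O)[nH]2)cc1` in this assay gives 247000000 nM. Compound 1 stands with the higher of the two numbers, but the gap to compound 2 lies within the scatter, so no order between them can be read. Compound 3 `O=C(CCc1nc2ccccc2c(=O)[nH]1)N/N=C/c1ccc(O)cc1` is not yet measured in this assay. It differs from compound 1 in one place: hydroxy in place of chloro on an aromatic carbon. Among the measured compounds shown here, no measured pair that differs in a single place exists, so the size of this step has no precedent here. With both measured numbers this close, no move beyond the scatter is expected in this assay. The expected step is a 1.3-fold lower number from compound 1 to compound 3 (0.10 log units; within the scatter). Compound 3 is estimated at 300000000 nM in this assay, in the range 150000000 nM to 700000000 nM.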

Compound 3, half-maximal inhibitory concentration: 238000000 nM
For compound 3 the middle estimate is 1.3-fold (0.10 log units) above the measured one, within the range that was stated.
By their numbers in this assay, from the lowest: compounds 3, 2 and 1 (each within the scatter of the next).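

Among the compounds shown here, this is the first single-place step: hydroxy in place of chloro on an aromatic carbon, para to a large group, gives a 1.6-fold lower number from compound 1 to compound 3 (0.20 log units; within the scatter) in this assay. Going from 4-chlorophenyl to 4-hydroxyphenyl adds a hydrogen-bond donor and a hydrogen-bond acceptor at this position, yet the two compounds cannot be told apart in this assay. Nothing at hand offers an account of this result.

As far as these compounds go, whether any group at this position can move the number beyond the scatter remains open, for example an amine, a carboxylic acid or a nitrile, or a bare phenyl with only hydrogen there. From the compounds shown here alone, the effect of chain length also remains open, since compound 2 differs from compound 1 in more than one place, and a longer chain carrying chloro at this position would give a single-place step.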